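The source may hold more compounds than are shown below. What is called first, only, known or untested is meant among the compounds shown, and "the series" means these compounds.

Of the compounds shown here, three with a shared core have been measured in a functional assay on EA.hy 926 cells (Homo sapiens) for cytotoxicity, read by MTT assay, with stated times of 24 h and 12 h, tested at 50 uM; a lower number here means a weaker effect, a higher number a stronger effect of the compound at the concentration tested. Compound 1 `COc1cc(/C=C/C(=O)O)ccc1OC(=O)c1nc(C)c(C)nc1C` gives 49.1%. Compound 2 `COc1ccc(/C=C/C(=O)O)cc1OC(=O)c1nc(C)c(C)nc1C` gives 160%. Compound 3 `Cc1nc(C)c(C(=O)Oc2ccc(/C=C/C(=O)O)cc2)nc1C` gives 74.1%, which is the second highest of the three numbers: compound 1 lies below it beyond the scatter, and compound 2 lies further above it, also beyond the scatter. The one single-change step among these is a number 25 percentage points higher from compound 1 to compound 3 (beyond the scatter), and that step concerns a methoxy group on the aromatic ring, not the acid end of the molecule.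

Compound 4 `CCOC(=O)/C=C/c1ccc(OC(=O)c2nc(C)c(C)nc2C)cc1` has not yet been measured in this assay. Its difference from compound 3 is ethyl in place of hydrogen on an oxygen next to a carbonyl group; read one bond further out, the carboxy group becomes an ethoxycarbonyl group. Among the measured compounds shown here, no measured step touches this part of the molecule, so the data give no guide to its direction or size. The expectation for compound 4 is therefore a step of a number 3.9 percentage points higher from compound 3 to compound 4 (within the scatter) from compound 3, which is no change beyond the scatter, with a wide range to allow for either direction. The estimate for compound 4 in this assay is 78%, between 45% and 125%.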

Compound 4, a percentage reported as activity, at one concentration (the size of the read-out at that concentration, not a potency): 62.6%
Estimate against measurement, compound 4: 15.4 percentage points above, within the range that was stated.
By their numbers in this assay, from the lowest: compound 1; then compound 4; then compound 3; then compound 2.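

In this assay, among the compounds shown here, putting ethyl in place of hydrogen on an oxygen next to a carbonyl group gives a number 11.5 percentage points lower from compound 3 to compound 4 (beyond the scatter), the first measured step at the acid end of the molecule rather than on the aromatic ring. This shows that the acid end is not a silent part of the structure: turning the carboxy group into an ethoxycarbonyl group lowers the number beyond the usual scatter, although the step is modest and the ester still gives a clear read-out, so the free carboxy group is not needed for an effect in this cell test. No measurement available here explains why the number moves in this direction.

The compounds shown leave open whether a methyl group or a longer chain such as butyl on this oxygen would lower the number further or less, and how an amide in place of the ester would read. They also leave open whether the same ethyl change would shift the number in the same direction for compound 1 and compound 2, which carry a methoxy group on the ring.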